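Methyl placement on the benzamide phenyl ring

The source may report more compounds than this note shows. Statements on the series, on what has been measured and on what is new or still open speak of the compounds shown alone.

In an assay for inhibition of very long chain fatty acid elongase 6 (Homo sapiens) (on this read-out higher numbers stand for weaker inhibition and lower numbers for stronger inhibition), compound 1 `O=C1Nc2ccc(Cl)cc2C(CNC(=O)c2ccccc2F)(C(F)(F)F)O1` gives 539 nM. Compound 2 `Cc1ccc(C(=O)NCC2(C(F)(F)F)OC(=O)Nc3ccc(Cl)cc32)cc1` gives 38 nM, and compound 3 `Cc1cccc(C(=O)NCC2(C(F)(F)F)OC(=O)Nc3ccc(Cl)cc32)c1` gives 437 nM, which is the second highest of the three numbers. The step of a 14-fold lower number from compound 1 to compound 2 (1.15 log units; beyond the scatter) is large, a 1.2-fold lower number from compound 1 to compound 3 (0.09 log units; within the scatter) stays within the scatter, and a 12-fold higher number from compound 2 to compound 3 (1.06 log units; beyond the scatter) is again large. Compound 4 `Cc1ccccc1C(=O)NCC1(C(F)(F)F)OC(=O)Nc2ccc(Cl)cc21` differs from compound 3 by 2-methylphenyl in place of 3-methylphenyl on a carbonyl carbon. Going by the values given here, the steps that bear on this are a 12-fold higher number from compound 2 to compound 3 (1.06 log units; beyond the scatter) and a 1.2-fold lower number from compound 1 to compound 3 (0.09 log units; within the scatter): shifting the methyl once already gave a large step, while compound 1, carrying 2-fluorophenyl with 539 nM, sits close to compound 3. A step of a 1.4-fold higher number from compound 3 to compound 4 (0.14 log units; within the scatter) is therefore expected, within the scatter or slightly upward. Compound 4 is estimated at 600 nM, range 250 nM to 1500 nM.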

Compound 4, half-maximal inhibitory concentration: 971 nM
For compound 4 the middle estimate is 1.6-fold (0.21 log units) below the measured one, and the stated range covers the measured number.
By their numbers in this assay, from the lowest: compound 2; then compounds 3, 1 and 4 (each within the scatter of the next, the first and the last beyond it).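

Shifting to 2-methylphenyl gives a further rise (a 2.2-fold higher number from compound 3 to compound 4 (0.35 log units; beyond the scatter)), so the 2-methylphenyl and 3-methylphenyl placements are distinguishable on this carbonyl carbon, and the gap to the 4-methylphenyl compound widens (a 26-fold higher number from compound 2 to compound 4 (1.41 log units; beyond the scatter)). Methyl in place of fluoro on an aromatic carbon stays within the scatter (a 1.8-fold higher number from compound 1 to compound 4 (0.26 log units; within the scatter)) in this read-out (this assay). Nothing available here accounts for these steps.

Open, from the compounds shown here alone, is whether a 4-ethylphenyl or 4-methoxyphenyl group on the carbonyl carbon would keep the low number of compound 2 (38 nM).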